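The source may hold more compounds than are shown below. What is called first, only, known or untested is meant among the compounds shown, and "the series" means these compounds.

Compound 1 `Cc1ccc(C(=O)NCc2ccc(CNS(=O)(=O)c3ccc(C)cc3)cc2)cc1` stands at the top of the numbers seen so far in this series. In an assay on MDA-MB-231 cells for binding affinity to C-X-C chemokine receptor type 4 (Homo sapiens), read by immunofluorescence and microscopy, with stated times of 10 min and 30 min (on this read-out higher numbers stand for an effect only at larger amounts of compound and lower numbers for an effect already at smaller amounts), compound 1 gives 1000 nM, the highest of the three measured compounds. Compound 2 `Cc1ccc(C(=O)NCc2ccc(CNS(=O)(=O)c3ccccc3)cc2)cc1` gives 100 nM in this assay, and compound 3 `O=C(NCc1ccc(CNS(=O)(=O)c2ccccc2)cc1)c1ccc(Cl)cc1` gives 100 nM. The step of a 10-fold lower number from compound 1 to compound 2 (1.00 log units; beyond the scatter) shows that removing the methyl from the carbonyl-side ring lowers the number by a modest but real margin, while the step of no change at the digits printed from compound 2 to compound 3 (within the scatter) shows that exchanging methyl for chloro at the same place leaves the number where it was. Compound 4 `Cc1ccc(S(=O)(=O)NCc2ccc(CNC(=O)c3cccc(C)c3)cc2)cc1` keeps every atom of compound 1 and differs only in this: 3-methylphenyl in place of 4-methylphenyl on a carbonyl carbon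

Among the measured compounds shown here, no measured step moves the methyl to another position of that ring, so the nearest guide is the step from compound 1 to compound 2, which says the ring tolerates change at this carbonyl-side position. The change to compound 4 is expected to give a small lowering or none beyond the scatter, with the estimated step of a 2.0-fold lower number from compound 1 to compound 4 (0.30 log units; within the scatter). For compound 4 the expected value in this assay is 500 nM, with a range from 150 nM to 2000 nM.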

Compound 4, effective concentration (reported as EC, without a stated level of effect): 1000 nM
Compound 4: middle estimate off by 2.0-fold (0.30 log units), on the low side, and the stated range covers the measured number.
By their numbers in this assay, from the lowest: compounds 2 and 3 (each within the scatter of the next); then compounds 1 and 4 (each within the scatter of the next).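

In this assay, 3-methylphenyl in place of 4-methylphenyl on a carbonyl carbon gives no change at the digits printed from compound 1 to compound 4 (within the scatter), so at this position the place of the methyl on the ring makes no difference that can be read. Read from the structures, the methyl lost in a 10-fold lower number from compound 1 to compound 2 (1.00 log units; beyond the scatter) sits on the ring of the sulfonyl group and not on this ring, so that step says nothing about this position, whereas no change at the digits printed from compound 2 to compound 3 (within the scatter) is on this ring and, like the new step, stays within the scatter. Nothing at hand explains why the methyl's place on this ring leaves the number unmoved.

Going by these compounds, whether this ring also accepts a carboxylic acid, an amine or a longer chain such as butyl remains open. Also open, on these data alone, is whether the 3-methylphenyl group behaves alike when the sulfonyl ring carries no methyl, as in compound 2.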